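Swapping the halogenated ring in a nucleoside-linked benzophenone series

A few compounds are considered here, and "the series" means these few. Any claim that something is new, unique, unknown or untested is made for them only; others in the source may bear on it.

Measured compounds:
- Compound 1 `COc1cccc(C(=O)c2ccc(OC)c(OC(=O)CCC(=O)OC[C@@H]3C=C[C@H](n4cc(C)c(=O)[nH]c4=O)O3)c2)c1`: 1580 nM
- Compound 2 `COc1ccc(C(=O)c2ccc(F)cc2)cc1OCC(=O)OC[C@@H]1C=C[C@H](n2cc(C)c(=O)[nH]c2=O)O1`: 36300 nM
- Compound 3 `COc1ccc(C(=O)c2ccc([N+](=O)[O-])cc2)cc1OC(=O)CCC(=O)OC[C@@H]1C=C[C@H](n2cc(C)c(=O)[nH]c2=O)O1`: 21100 nM

Of the compounds shown here, three have been tested in a functional assay on HeLa cells (Homo sapiens) for antiproliferative activity, read by MTT assay, with a stated time of 48 h; a higher number here means a weaker inhibitor, a lower number a stronger inhibitor. Compound 2 gives the highest of the three numbers; its nearest neighbour is compound 3, whose value lies within the scatter of that of compound 2, while compound 1 stands far lower, beyond the scatter. Among the compounds with values here, only one step between measured compounds changes a single place: a 13-fold higher number from compound 1 to compound 3 (1.13 log units; beyond the scatter). That step exchanged the ring attached to a carbonyl carbon and produced a large shift, so a change at that same place can matter.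

Compound 4 `COc1ccc(C(=O)c2ccccc2Cl)cc1OCC(=O)OC[C@@H]1C=C[C@H](n2cc(C)c(=O)[nH]c2=O)O1` is not yet measured. It differs from compound 2 in one place: 2-chlorophenyl in place of 4-fluorophenyl on a carbonyl carbon. Within the data shown here, no measured pair shows this particular exchange, so the only guide is that a ring swap on the carbonyl carbon once moved the number a great deal, and that compound 2 already sits at the weak end of the series. Without a closer precedent, the expected step of a 1.2-fold lower number from compound 2 to compound 4 (0.08 log units; within the scatter) is kept near zero, with a wide range to allow for a move in either direction. Compound 4 is therefore estimated at 30000 nM, with a range from 9000 nM to 100000 nM.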

Compound 4, half-maximal inhibitory concentration: 45800 nM
Compound 4: the middle estimate sits 1.5-fold (0.18 log units) below what was measured; the measured number falls inside the stated range.
By their numbers in this assay, from the lowest: compound 1; then compounds 3, 2 and 4 (each within the scatter of the next, the first and the last beyond it).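

In this assay, replacing 4-fluorophenyl with 2-chlorophenyl on the carbonyl carbon gives a 1.3-fold higher number from compound 2 to compound 4 (0.10 log units; within the scatter), so this exchange leaves the compound where it was, at the weak end of the series. The position therefore does not respond strongly to every ring exchange: the earlier step, a 13-fold higher number from compound 1 to compound 3 (1.13 log units; beyond the scatter), showed that a swap here can matter, whereas this pair shows that one halogenated phenyl ring can stand in for another with no change that can be read, at least on the core shared by compound 2 and compound 4. No supporting measurement is available to explain this result.

Because the halogen and its place on the ring change together in this step, the pair cannot show what either change does alone, and a 4-chlorophenyl or 2-fluorophenyl ring would be needed to separate them. As far as these compounds go, it also remains open whether a ring of a different kind on this same core, such as one carrying an amine or a carboxylic acid, would move the number beyond the scatter.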